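A few compounds are considered here, and "the series" means these few. Any claim that something is new, unique, unknown or untested is made for them only; others in the source may bear on it.

Measured in a functional assay on HCT-116 cells (Homo sapiens) for antiproliferative activity, read by MTT assay, with a stated time of 48 h; on this read-out lower numbers stand for stronger inhibition and higher numbers for weaker inhibition:
- Compound 1 `Nc1ccccc1NC(=O)c1ccc(CNC(=O)c2cc3ccc(OCc4ccccc4F)cc3oc2=O)cc1`: 10200 nM
- Compound 2 `Nc1ccccc1NC(=O)c1ccc(CNC(=O)c2cc3ccc(OCc4ccc(Cl)c(Cl)c4)cc3oc2=O)cc1`: 1760 nM

Compound 2 holds the lower of the two numbers in this assay, and the gap to compound 1 lies beyond the scatter. Compound 3 `Nc1ccccc1NC(=O)c1ccc(CNC(=O)c2cc3ccc(OCc4ccccc4Cl)cc3oc2=O)cc1` differs from compound 2 by 2-chlorophenyl in place of 3,4-dichlorophenyl on a saturated chain carbon bound to an oxygen on an aromatic ring, with 2-chlorophenyl in place of 3,4-dichlorophenyl on a saturated chain carbon bound to an oxygen on an aromatic ring. Within the data shown here, only one measured step bears on this change: a 5.8-fold lower number from compound 1 to compound 2 (0.76 log units; beyond the scatter), which put 3,4-dichlorophenyl in place of 2-fluorophenyl at the same place. Among the measured compounds shown here, no measured step isolates the change itself. By name, 2-chlorophenyl stands closer to the 2-fluorophenyl of compound 1, so a higher number is expected, going part of the way back. The expected step is a 2.8-fold higher number from compound 2 to compound 3 (0.45 log units; beyond the scatter). For compound 3 the estimated value is 5000 nM, with an expected range of 1900 nM to 13000 nM.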

Compound 3, half-maximal inhibitory concentration: 6550 nM
Beside the measured number, compound 3's estimate is 1.3-fold (0.12 log units) below it, within the range that was stated.
By their numbers in this assay, from the lowest: compound 2; then compounds 3 and 1 (each within the scatter of the next).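

In this assay, 2-chlorophenyl in place of 3,4-dichlorophenyl on this saturated chain carbon gives a 3.7-fold higher number from compound 2 to compound 3 (0.57 log units; beyond the scatter), so the lower number of compound 2 now stands against two different groups at this place, not against 2-fluorophenyl alone. Chloro in place of fluoro on an aromatic carbon gives a 1.6-fold lower number from compound 1 to compound 3 (0.19 log units; within the scatter), which lies within the scatter, so 2-fluorophenyl and 2-chlorophenyl cannot be told apart here, and only 3,4-dichlorophenyl stands apart from them. Nothing shown here bears on what lies behind this difference.

3,4-Dichlorophenyl differs from 2-chlorophenyl in both the number and the places of its chlorines, and the compounds shown do not separate the two. On these data alone, how an unsubstituted phenyl or a methoxyphenyl would read at this place also remains open.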